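A few compounds are considered here, and "the series" means these few. Any claim that something is new, unique, unknown or untested is made for them only; others in the source may bear on it.

Measured so far in an assay for inhibition of Pro-cathepsin H (Homo sapiens), read by fluorescence, tested at 50 uM; on this read-out higher numbers stand for more inhibition at the one concentration tested (going by the name of the read-out) and lower numbers for less inhibition:
- compound 1 `COc1nc(N[C@H](CCC(=O)O)C(=O)O)nc(OC)n1` gives 0.34%
- compound 2 `COc1nc(OC)nc(Sc2ccccc2C(=O)N[C@@H](C)C(=O)OCc2ccccc2)n1` gives 1.34%
- compound 3 `CC(C)(C)c1ccccc1Nc1nc(Cl)nc(Cl)n1` gives -4.16%

Among the measured compounds shown here, all three numbers sit close to zero, and no step between any pair of them is recorded. The number for compound 3 is the smallest of the three, but its gap to compound 1 and its gap to compound 2 both fall within the usual scatter of this assay, so the three compounds cannot be told apart on what has been measured; none of them shows inhibition at the single concentration tested.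

Compound 4 `Clc1nc(Cl)nc(Nc2ccccc2Br)n1` is the next compound for this assay. It differs from compound 3 in one place: bromo in place of tert-butyl on an aromatic carbon. The rest of compound 3 is kept unchanged. For the measured compounds named here, with no step between measured compounds to lean on, and with compound 3 at -4.16% and the other two compounds likewise near zero, no step beyond the scatter is expected in this assay: the estimated step of a number 4.2 percentage points higher from compound 3 to compound 4 (within the scatter) is small and of uncertain direction. Compound 4 is therefore expected to give about 0%, with a likely range from -8% to 8%.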

Compound 4, a percentage reported as inhibition, at one concentration (the size of the read-out at that concentration, not a potency): 4.52%
Compound 4: middle estimate off by 4.5 percentage points, on the low side; low and high end bracket the measured number.
By their numbers in this assay, from the lowest: compounds 3, 1, 2 and 4 (each within the scatter of the next).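

In this assay, the series now has its first change in one place: bromo in place of tert-butyl on an aromatic carbon, ortho to a group of 9 heavy atoms, gives a number 8.7 percentage points higher from compound 3 to compound 4 (within the scatter) and so no difference that can be read. Replacing a group of 4 heavy atoms with a single heavy atom at this position therefore leaves the two compounds indistinguishable, and neither shows inhibition that stands apart from the other compounds measured here. This holds for this one pair only, and no measurement at hand offers an explanation for the result.

From the compounds shown here alone, whether a different group on the same aromatic carbon, such as an amine, a methoxy group or a carboxylic acid, would move the read-out beyond the scatter remains open. Also open, going by these compounds, is whether replacing either chloro group of compound 4 with an amine or a longer chain would produce any inhibition in this assay at all.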